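This account rests on a few compounds, and the source may have more. Where it says the series, first, only, none or still open, it means among the compounds named here.

Of the compounds shown here, three sharing one core have been tested in a functional assay on HeLa cells (Homo sapiens) for cytotoxicity, read by CCK-8 assay; on this read-out higher numbers stand for weaker inhibition and lower numbers for stronger inhibition. Compound 1 `Oc1ccc(-c2cc(-c3ccco3)cc(-c3ccc(O)cc3)n2)cc1` reaches only the limit of this assay, > 50000 nM. Compound 2 `Oc1ccc(-c2cc(-c3cccnc3)cc(-c3ccccc3O)n2)cc1` likewise gives only a limit, > 50000 nM. Compound 3 `Oc1ccc(-c2cc(-c3cccnc3)cc(-c3cccc(O)c3)n2)cc1` also stops at a limit, > 50000 nM. Compound 3 thus stands exactly where every measured value stands: at the limit described by the limit of > 50000 nM in this assay, at which 3 of the 3 values shown sit. Among the compounds with values here, the single step between measured neighbours, a step that the two limits leave unreadable from compound 2 to compound 3, has no readable size; the limit of > 50000 nM in this assay, at which 3 of the 3 values shown sit, covers both of its ends, so no step of known size exists to lean on.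

Compound 4 `Oc1ccc(-c2cc(-c3cccnc3)cc(-c3ccc(O)cc3)n2)cc1` is not yet measured. It differs from compound 3 by 4-hydroxyphenyl in place of 3-hydroxyphenyl on an aromatic carbon. Since every measured value, including that of compound 3, sits at the limit (the limit of > 50000 nM in this assay, at which 3 of the 3 values shown sit), the most likely outcome is that compound 4 also returns a limit rather than a number, and the step that the limit leaves unreadable from compound 3 to compound 4 is expected to show nothing beyond the scatter. Compound 4 is therefore estimated at 100000 nM, with a range from 30000 nM to 500000 nM.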

Compound 4, half-maximal inhibitory concentration: 600 nM
Compound 4: the middle estimate sits 170-fold (2.22 log units) above what was measured; measured number below the stated range.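

In this assay, the place next to the ring nitrogen proves sensitive to where the hydroxyl sits on its phenyl group, even though the groups exchanged hold the same atoms: 4-hydroxyphenyl in place of 3-hydroxyphenyl gives an at least 83-fold lower number from compound 3 to compound 4 (1.92 log units; beyond the scatter), and 4-hydroxyphenyl in place of 2-hydroxyphenyl gives an at least 83-fold lower number from compound 2 to compound 4 (1.92 log units; beyond the scatter). The 4-hydroxyphenyl group is not enough by itself, since compound 1 also carries it there, and pyridin-3-yl in place of furan-2-yl gives an at least 83-fold lower number from compound 1 to compound 4 (1.92 log units; beyond the scatter). The step between compound 2 and compound 3 still cannot be read, and those compounds remain limits, not numbers, together with compound 1: the limit of > 50000 nM in this assay, at which 3 of the 4 values shown sit.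

Going by these compounds, what an amine or a carboxylic acid would do in place of the hydroxyl on the 4-hydroxyphenyl group stays open. So does whether a pyrimidine ring or a simple phenyl could stand in for pyridin-3-yl.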